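A few compounds are considered here, and "the series" means these few. Any claim that something is new, unique, unknown or untested is made for them only; others in the source may bear on it.

Two chalcone-type compounds share one core. Compound 1 `COc1cc(-c2cc(/C=C/C(=O)c3ccc(N)cc3)[nH]n2)cc(OC)c1OC` gives -98% in a functional assay on SK-OV-3 cells (Homo sapiens) for cytotoxicity, read by sulforhodamine B assay, with a stated time of 48 h, tested at 100 uM (a lower number here means a stronger effect, a higher number a weaker effect of the compound at the concentration tested), while compound 2 `COc1ccc(C(=O)/C=C/c2cc(-c3cc(OC)c(OC)c(OC)c3)n[nH]2)cc1` gives -41%, the higher of the two numbers; the step of a number 57 percentage points higher from compound 1 to compound 2 (beyond the scatter) is large and beyond the scatter. Compound 3 `COc1cc(-c2cc(/C=C/C(=O)c3ccc(F)c(F)c3)[nH]n2)cc(OC)c1OC` differs from compound 2 by 3,4-difluorophenyl in place of 4-methoxyphenyl on a carbonyl carbon. Going by the values given here, no measured step exchanges one aryl group for another, so the single known step, which swapped amino for methoxy, gives only a loose guide. Compound 3 is therefore expected to show -60%, between -100% and -10%, an estimated step of a number 19 percentage points lower from compound 2 to compound 3 (beyond the scatter).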

Compound 3, a percentage reported as activity, at one concentration (the size of the read-out at that concentration, not a potency): -5%
Estimate against measurement, compound 3: 55 percentage points below; measured number outside the range, above it.
By their numbers in this assay, from the lowest: compound 1; then compound 2; then compound 3.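

In this assay, 3,4-difluorophenyl in place of 4-methoxyphenyl on the carbonyl carbon gives a number 36 percentage points higher from compound 2 to compound 3 (beyond the scatter) as its step, and the same group in place of 4-aminophenyl gives a number 93 percentage points higher from compound 1 to compound 3 (beyond the scatter) across the series. The position therefore tolerates no free exchange of aryl groups, and compound 3 shows the weakest effect of the three. Nothing at hand explains these steps.

On these data alone, it remains open whether 4-fluorophenyl would behave like 3,4-difluorophenyl, and whether 4-dimethylaminophenyl would keep the effect of compound 1.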